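Removing the Aryl Group Entirely: What to Expect

A few compounds are considered here, and "the series" means these few. Any claim that something is new, unique, unknown or untested is made for them only; others in the source may bear on it.

Compound 2 `N#Cc1ccc(C2=C(c3ccccc3)C3(C=CC(=O)C=C3)OC2=O)cc1` holds the lowest of the two numbers recorded so far, though its gap to compound 1 is within the scatter. In a functional assay on MDA-MB-231 cells (Homo sapiens) for antiproliferative activity, read by MTT assay, with a stated time of 48 h (on this read-out lower numbers stand for stronger inhibition and higher numbers for weaker inhibition), compound 2 gives 8740 nM, while compound 1 `COc1ccc(F)cc1C1=C(c2ccccc2)C2(C=CC(=O)C=C2)OC1=O` gives 10000 nM. The step of a 1.1-fold lower number from compound 1 to compound 2 (0.06 log units; within the scatter) lies within the scatter, so the two compounds cannot be ordered on this read-out. Compound 3 `O=C1C=CC2(C=C1)OC(=O)C=C2c1ccccc1` has not yet been measured in this assay. It differs from compound 2 in one place: hydrogen in place of 4-cyanophenyl on a double-bonded ring carbon. Among the compounds with values here, only one measured step exists, and it exchanges one aryl ring for another on the same carbon rather than removing the ring altogether; that step, a 1.1-fold lower number from compound 1 to compound 2 (0.06 log units; within the scatter), was small. It offers no direct guide to the loss of the whole 4-cyanophenyl group, and the direction of the change cannot be read from the data. Compound 3 is therefore expected to give about 12000 nM in this assay, within a range from 4000 nM to 40000 nM. This estimate corresponds to an expected step of a 1.4-fold higher number from compound 2 to compound 3 (0.14 log units; within the scatter), which is taken to remain within the scatter, with wide uncertainty.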

Compound 3, half-maximal inhibitory concentration: 15900 nM
Compound 3: the middle estimate sits 1.3-fold (0.12 log units) below what was measured; the measured number falls inside the stated range.
By their numbers in this assay, from the lowest: compounds 2, 1 and 3 (each within the scatter of the next).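

In this assay, taking the aryl ring off this double-bonded ring carbon altogether gives a 1.8-fold higher number from compound 2 to compound 3 (0.26 log units; within the scatter) and, from the other aryl compound, a 1.6-fold higher number from compound 1 to compound 3 (0.20 log units; within the scatter), so on this read-out neither 4-cyanophenyl nor 5-fluoro-2-methoxyphenyl can be told apart from hydrogen at this position. Within the data shown here, the earlier pair compared only one aryl ring with another, whereas these steps compare each ring with no ring at all, and the loss of the whole group still stays within the scatter. Nothing available here bears on the reason for this result.

All three compounds lie within the scatter of one another and only two aryl rings and hydrogen are shown at this carbon, so it remains open whether any group placed there can move the number beyond the scatter. On these data alone, it also remains open whether an amine, a carboxylic acid or a longer alkyl chain on this carbon would do so, and what the phenyl group on the ring atom next to it contributes to the activity of the shared core.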